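The source may report more compounds than this note shows. Statements on the series, on what has been measured and on what is new or still open speak of the compounds shown alone.

In a functional assay on HepG2 cells (Homo sapiens) for cytotoxicity, read by MTT assay, with a stated time of 48 h (a lower number here means a stronger inhibitor, a higher number a weaker inhibitor), compound 1 `O=C(CSc1nnc(-c2ccncc2)o1)N/N=C/c1ccccc1F` gives 16000 nM, while compound 2 `O=C(CSc1nnc(-c2ccncc2)o1)N/N=C/c1ccccc1O` gives 3510 nM, so that compound 2 stands at the lowest of the two numbers, after a 4.6-fold lower number from compound 1 to compound 2 (0.66 log units; beyond the scatter). Compound 3 `O=C(CSc1nnc(-c2ccncc2)o1)N/N=C/c1cc(Cl)ccc1O` differs from compound 2 by chloro in place of hydrogen on an aromatic carbon, the newcomer sitting para to the hydroxy group. Among the compounds with values here, no measured step touches that position; the only step known concerns a different group, so it gives no direct guide. The step of a 1.2-fold lower number from compound 2 to compound 3 (0.07 log units; within the scatter) is therefore expected to be small, likely within the scatter. Compound 3 is estimated at 3000 nM, in a range from 1000 nM to 10000 nM.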

Compound 3, half-maximal inhibitory concentration: 3970 nM
Compound 3: middle estimate off by 1.3-fold (0.12 log units), on the low side; the measured number falls inside the stated range.
By their numbers in this assay, from the lowest: compounds 2 and 3 (each within the scatter of the next); then compound 1.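

In this assay, adding chloro para to the hydroxy group leaves the number within the scatter (a 1.1-fold higher number from compound 2 to compound 3 (0.05 log units; within the scatter)), so this position accepts chloro without a measurable change. The 5-chloro-2-hydroxyphenyl group also keeps the advantage over 2-fluorophenyl (a 4.0-fold lower number from compound 1 to compound 3 (0.61 log units; beyond the scatter)). No evidence is available to explain either result. Still open, as far as these compounds go, is whether a larger or different group at this position, such as methoxy, an amine or a carboxylic acid, would also leave the number unchanged. From the compounds shown here alone, it is also open whether chloro would behave the same way without the hydroxy group.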